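A few compounds are considered here, and "the series" means these few. Any claim that something is new, unique, unknown or untested is made for them only; others in the source may bear on it.

For the measured compounds named here, in an ADME assay on HEK293-A cells for inhibition of sodium channel protein type 1 subunit alpha/beta-1/beta-2 (Homo sapiens), read by patch clamp (a lower number here means a stronger inhibitor, a higher number a weaker inhibitor), compound 3 `Cn1nccc1[C@H]1CCC[C@@H]1Oc1cc(F)c(S(=O)(=O)Nc2nccs2)cc1F` gives 13000 nM, the only number among the three measured compounds. Compound 1 `Cn1nccc1[C@H]1CCCC[C@@H]1Oc1cc(F)c(S(=O)(=O)Nc2ccncn2)c(F)c1` reaches only the limit of the assay, > 100000 nM. Compound 2 `Cn1nccc1CCOc1cc(F)c(S(=O)(=O)Nc2ncns2)cc1F` likewise stops at the assay limit, > 100000 nM. Going by the values given here, compound 3 thus stands apart from the limit of > 100000 nM in this assay, at which 2 of the 3 values shown sit, as the one compound with a measured value. Compound 4 `Cn1nccc1[C@H]1CCC[C@@H]1Oc1cc(F)c(S(=O)(=O)Nc2ncns2)cc1F` differs from compound 3 in a single place: 1,2,4-thiadiazol-5-yl in place of 1,3-thiazol-2-yl on a sulfonamide nitrogen. Among the compounds with values here, no measured pair shows this exchange on its own, so its size is not known from the data. In this assay the expected step is a 1.2-fold higher number from compound 3 to compound 4 (0.09 log units; within the scatter), which stays within the usual scatter. Compound 4 is therefore estimated at 16000 nM, with a range from 5000 nM to 60000 nM.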

Compound 4, half-maximal inhibitory concentration in the sodium channel protein type 1 subunit alpha/beta-1/beta-2 assay: 26000 nM
Compound 4: middle estimate off by 1.6-fold (0.21 log units), on the low side, and the stated range covers the measured number.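

For the compounds shown here, this is the first pair that differs only in the group on the sulfonamide nitrogen, and in the sodium channel protein type 1 subunit alpha/beta-1/beta-2 assay the exchange gives a 2.0-fold higher number from compound 3 to compound 4 (0.30 log units; within the scatter), so the added ring nitrogen leaves no change that can be told from scatter. In a physicochemical assay for solubility, read by HPLC, measured as thermodynamic solubility, with a stated time of 4 h, at pH 6.8 (on this read-out lower numbers stand for lower solubility and higher numbers for higher solubility), compound 3 gives 250000 nM. In the physicochemical assay compound 4 gives > 1900000 nM, which is a limit of the assay and not a number. In the physicochemical assay the same exchange gives an at least 7.6-fold higher number from compound 3 to compound 4 (0.88 log units; beyond the scatter), and that reading rests on a limit of the assay for compound 4: the limit of > 1900000 nM in the physicochemical assay, at which 1 of the 2 values shown sits.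

On these data alone, the true solubility of compound 4 stays open. So does whether a pyridin-2-yl ring or a plain methyl group on the sulfonamide nitrogen would shift either read-out.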